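Methoxy for fluoro: next step in the series

This account rests on a few compounds, and the source may have more. Where it says the series, first, only, none or still open, it means among the compounds named here.

Measured so far:
compound 1, `O=C(CCC(=O)c1cccs1)NCCCO`: 300 mg/kg
compound 2, `O=C1CCC2(c3ccc(F)cc3)OCCCN12`: 100 mg/kg

In a functional assay on the whole organism (Central nervous system) with Mus musculus as the target (on this read-out lower numbers stand for an effect already at smaller amounts and higher numbers for an effect only at larger amounts of compound), compound 2 gives 100 mg/kg. Compound 1 gives 300 mg/kg, a higher number, and the gap between the two stands beyond the scatter, so compound 2 holds the lowest number of the two measured. Compound 3, `COc1ccc(C23CCC(=O)N2CCCO3)cc1`, is not yet measured in this assay. It differs from compound 2 in one place: methoxy in place of fluoro on an aromatic carbon. Going by the values given here, no pair of measured compounds tracks this change, so nothing here tells the direction or size of its effect. The expected outcome for compound 3 is a step of no change at the digits printed from compound 2 to compound 3 (within the scatter) from compound 2, not beyond the scatter in either direction. As far as these compounds go, compound 3 is estimated at 100 mg/kg, with a range from 40 mg/kg to 300 mg/kg, the width of the range reflecting that the change is untested.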

Compound 3, dose for half-maximal effect: < 150 mg/kg
Compound 3 was reported as a limit (the forecaster's own chance of this, stated with the estimate: 15%); the middle value is on the limit's open side.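

Going by these compounds alone, compound 3 carries only a limit, < 150 mg/kg, so no step between compound 2 and compound 3 can be read. The compounds shown leave open whether methoxy in place of fluoro on an aromatic carbon moves the read-out beyond the scatter, in either direction.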